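The source may report more compounds than this note shows. Statements on the series, on what has been measured and on what is new or still open speak of the compounds shown alone.

Working notes on the series. Compound 1 `CC(C)c1ccc(COc2cc([N+](=O)[O-])ccc2NS(C)(=O)=O)cc1` gives 7450 nM in an assay on SK-BR-3 cells for inhibition of Aromatase (Homo sapiens); a lower number here means a stronger inhibitor, a higher number a weaker inhibitor. Compound 2 `CS(=O)(=O)Nc1ccc([N+](=O)[O-])cc1OCc1ccc(Cl)cc1` gives 290 nM; the step of a 26-fold lower number from compound 1 to compound 2 (1.41 log units; beyond the scatter) is the largest in the set. Compound 3 `CN(c1ccc([N+](=O)[O-])cc1OCc1ccc(Cl)cc1)S(C)(=O)=O` gives 2400 nM, the step being an 8.3-fold higher number from compound 2 to compound 3 (0.92 log units; beyond the scatter); compound 3 thus stands second highest of the three numbers, nearer to compound 1 than to compound 2. Compound 4 `CN(c1ccc([N+](=O)[O-])cc1OCc1ccc(-c2ccccc2)cc1)S(C)(=O)=O` is not yet measured; its change from compound 3 is phenyl in place of chloro on an aromatic carbon, para to a large group. The step of a 26-fold lower number from compound 1 to compound 2 (1.41 log units; beyond the scatter) bears on it, since there a smaller group replacing a larger one at the same position gave a large fall; the reverse direction here suggests a rise. The step of an 8.3-fold higher number from compound 2 to compound 3 (0.92 log units; beyond the scatter) does not touch this position. Compound 4 is therefore expected to give 9000 nM (range 2500 nM to 35000 nM), an expected step of a 3.8-fold higher number from compound 3 to compound 4 (0.57 log units; beyond the scatter).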

Compound 4, half-maximal inhibitory concentration: 650 nM
Estimate against measurement, compound 4: 14-fold (1.14 log units) above; the measured number lies below the stated range.
By their numbers in this assay, from the lowest: compound 2; then compound 4; then compound 3; then compound 1.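

Phenyl in place of chloro on this aromatic carbon gives a 3.7-fold lower number from compound 3 to compound 4 (0.57 log units; beyond the scatter) in this pair, so a ring of six heavy atoms is accepted here and does not raise the number. Group size alone therefore does not order this position: chloro in place of isopropyl gave a 26-fold lower number from compound 1 to compound 2 (1.41 log units; beyond the scatter) with hydrogen on the sulfonamide nitrogen, so a larger group raised the number there but lowered it here. Nothing measured accounts for this difference. The compounds shown leave open whether phenyl acts alike with hydrogen on the sulfonamide nitrogen, and how an amine or a methoxy group would read at this position.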